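The compounds below may be only part of what the source reports. "The series", "measured", "known", "first", "only" and "open" are said of these compounds alone.

Measured so far:
Compound 2 `CNC(=O)c1cccn(Cc2ccccc2)c1=O`: 78 ug/mL
Compound 1 `CNC(=O)c1cc(C(=O)NC2CCC2)cn(Cc2cccnc2)c1=O`: >= 99 ug/mL

For the measured compounds named here, in a physicochemical assay for solubility (on this read-out higher numbers stand for higher solubility and lower numbers for lower solubility), compound 2 gives 78 ug/mL, the only plain number here. Compound 1 sits at the limit of >= 99 ug/mL in this assay, at which 1 of the 2 values shown sits, which is a limit of the assay rather than a number.

Compound 3 `CNC(=O)c1cc(C(=O)NCCC(C)C)cn(Cc2ccccc2)c1=O` differs from compound 2 by isopentylcarbamoyl in place of hydrogen on an aromatic carbon. Going by the values given here, no measured pair shows the effect of such a change, so the expectation rests on the structural change alone. The expected step is a 3.1-fold lower number from compound 2 to compound 3 (0.49 log units; beyond the scatter), a fall beyond the usual scatter. Compound 3 is estimated at 25 ug/mL, likely between 6 ug/mL and 90 ug/mL.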

Compound 3, solubility: 10 ug/mL
The estimate for compound 3 lay 2.5-fold (0.40 log units) above the measured number; the measured number falls inside the stated range.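

For the compounds shown here, compound 2 and compound 3 form the first pair here that differs in only one place, so this change can be read on its own in this assay. Putting isopentylcarbamoyl in place of hydrogen on the aromatic carbon two atoms from the ring nitrogen gives a 7.8-fold lower number from compound 2 to compound 3 (0.89 log units; beyond the scatter) for this pair. The benzyl and methylcarbamoyl groups stay the same, so this position does respond to substitution.

As far as these compounds go, whether a shorter chain, an amine or a carboxylic acid at this position would give a similar fall remains open. Nothing shown gives a reason for the size of this step.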